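Swapping Fluoro for Methyl on the Aromatic Ring

A few compounds are considered here, and "the series" means these few. Any claim that something is new, unique, unknown or untested is made for them only; others in the source may bear on it.

In a functional assay on KB cells (Homo sapiens) for cytotoxicity (a lower number here means that less compound is needed, a higher number that more compound is needed for the effect), compound 1 `COC1=C(C)C(=O)/C(=C(O)/C=C/c2ccc(OC)cc2)C(=O)C1(C)C` gives 3.6 ug/mL, compound 2 `COC1=C(C)C(=O)/C(=C(O)/C=C/c2ccc(O)cc2)C(=O)C1(C)C` gives 3.8 ug/mL and compound 3 `COC1=C(C)C(=O)/C(=C(O)/C=C/c2ccc(F)cc2)C(=O)C1(C)C` gives 3.7 ug/mL, so compound 3 cannot be told apart from the other two. Compound 4 `COC1=C(C)C(=O)/C(=C(O)/C=C/c2ccc(C)cc2)C(=O)C1(C)C` keeps the shared core but has methyl in place of fluoro on an aromatic carbon. Going by the values given here, no measured step makes this exact change, but three change the group at that same place: a 1.1-fold higher number from compound 1 to compound 2 (0.02 log units; within the scatter), a 1.0-fold higher number from compound 1 to compound 3 (0.01 log units; within the scatter) and a 1.0-fold lower number from compound 2 to compound 3 (0.01 log units; within the scatter). All three lie within the scatter, so no real shift is expected here. The expected step is no change at the digits printed from compound 3 to compound 4 (within the scatter). Compound 4 is estimated at 3.7 ug/mL, with an expected range from 2.4 ug/mL to 5.5 ug/mL.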

Compound 4, concentration for half-maximal effect: 3.9 ug/mL
Compound 4: middle estimate off by 1.1-fold (0.02 log units), on the low side; measured number inside the range.
By their numbers in this assay, from the lowest: compounds 1, 3, 2 and 4 (each within the scatter of the next).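

Methyl now joins methoxy, hydroxy and fluoro at this place on the aromatic ring, and in this assay the step readings are a 1.1-fold higher number from compound 3 to compound 4 (0.02 log units; within the scatter) and a 1.0-fold higher number from compound 2 to compound 4 (0.01 log units; within the scatter) and a 1.1-fold higher number from compound 1 to compound 4 (0.03 log units; within the scatter) as well. All four groups at this position therefore cannot be told apart, and that now includes a group with a carbon atom attached directly to the ring. No data are available to explain this flat result.

As far as these compounds go, whether an amine, a carboxylic acid or a longer chain at this place would stand apart from these four remains open. So does the effect of changes elsewhere on the shared core.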